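A few compounds are considered here, and "the series" means these few. Any claim that something is new, unique, unknown or untested is made for them only; others in the source may bear on it.

Measured in a functional assay on MGC-803 cells (Homo sapiens) for inhibition, read by CCK-8 assay, with a stated time of 48 h; on this read-out higher numbers stand for weaker inhibition and lower numbers for stronger inhibition:
- compound 1 (`COc1cc(N(Cc2ccc(C)cc2)C(=O)CSC(=S)N2CCN(C(=O)OC(C)(C)C)CC2)cc(OC)c1OC`): 16700 nM
- compound 2 (`COc1ccc(CN(C(=O)CSC(=S)N2CCN(C(=O)OC(C)(C)C)CC2)c2cc(OC)c(OC)c(OC)c2)cc1Br`): 3710 nM
- compound 3 (`COc1ccc(CN(C(=O)CSC(=S)N2CCN(C(=O)OC(C)(C)C)CC2)c2cc(OC)c(OC)c(OC)c2)cc1N`): 184 nM

Compound 3 stands lowest of the three numbers. The largest step towards it is a 91-fold lower number from compound 1 to compound 3 (1.96 log units; beyond the scatter), and the smallest is a 20-fold lower number from compound 2 to compound 3 (1.30 log units; beyond the scatter). Compound 4 (`COc1ccc(CN(C(=O)CSC(=S)N2CCN(C(=O)OC(C)(C)C)CC2)c2cc(OC)c(OC)c(OC)c2)cc1O`) carries hydroxy in place of amino on an aromatic carbon, ortho to a methoxy group: hydroxy in place of amino on an aromatic carbon.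

Within the data shown here, no measured step makes this exchange. The nearest evidence is the large step of a 20-fold lower number from compound 2 to compound 3 (1.30 log units; beyond the scatter), at the same aromatic carbon, alongside the modest step of a 4.5-fold lower number from compound 1 to compound 2 (0.65 log units; beyond the scatter). Amino and hydroxy match in the counts above, so only a modest change is expected in this assay, towards a higher number. The expected size is a 2.2-fold higher number from compound 3 to compound 4 (0.34 log units; beyond the scatter). Compound 4 is estimated at 400 nM, with an expected range of 110 nM to 1800 nM.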

Compound 4, half-maximal inhibitory concentration: 82 nM
For compound 4 the middle estimate is 4.9-fold (0.69 log units) above the measured one, and the stated range ends above it.
By their numbers in this assay, from the lowest: compound 4; then compound 3; then compound 2; then compound 1.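

In this assay the aromatic carbon ortho to a methoxy group accepts hydroxy as well as amino, and the exchange gives a 2.2-fold lower number from compound 3 to compound 4 (0.35 log units; beyond the scatter). Hydroxy also stands well clear of the other groups, with a 45-fold lower number from compound 2 to compound 4 (1.66 log units; beyond the scatter) and a 200-fold lower number from compound 1 to compound 4 (2.31 log units; beyond the scatter), so amino is not required at this carbon for a low number. No measured data explain the small preference for hydroxy over amino.

Open, from the compounds shown here alone, is how a methylamino or acetamido group would read at this carbon. Also open, going by these compounds, is whether the same order of hydroxy and amino holds with a free piperazine amine in place of the tert-butyl carbamate.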